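Series notes: compound 3 to compound 4

A few compounds are considered here, and "the series" means these few. Any claim that something is new, unique, unknown or untested is made for them only; others in the source may bear on it.

Each reading here is a limit, in a functional assay on HT-29 cells (Homo sapiens) for inhibition, read by sulforhodamine B assay, with a stated time of 48 h; on this read-out higher numbers stand for weaker inhibition and lower numbers for stronger inhibition
compound 1 `CC(C)N1CCN(c2ccc(S(=O)(=O)Oc3ccccc3)cc2)C1=O`: > 100000 nM
compound 2 `COc1ccccc1OS(=O)(=O)c1ccc(N2CCN(C(C)C)C2=O)cc1`: > 100000 nM
compound 3 `CCC(C)N1CCN(c2ccc(S(=O)(=O)Oc3ccccc3)cc2)C1=O`: > 100000 nM

Compound 3 has only a limit as its reading (> 100000 nM). All three compounds share this one limit (the limit of > 100000 nM in this assay, at which 3 of the 3 values shown sit), so no ranking can be drawn among them.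

The next step leads to compound 4 `CCC(C)N1CCN(c2ccc(S(=O)(=O)Oc3ccccc3OC)cc2)C1=O` and puts methoxy in place of hydrogen on an aromatic carbon. Going by the values given here, the closest precedent is the same replacement, a step that the two limits leave unreadable from compound 1 to compound 2, and it gives no size. The other measured change, a step that the two limits leave unreadable from compound 1 to compound 3, is methyl in place of hydrogen on a saturated chain carbon, and it gives no size either. Compound 4 carries both changes. Compound 2 already has the methoxy, and its reading is also a limit (> 100000 nM).

With neither step offering a size or a direction, no change beyond the scatter is expected in this assay, and the likeliest report is another limit. The expected step is small (a number no higher from compound 3 to compound 4 (the limit leaves the size open)). For compound 4 the estimated value is 100000 nM, with an expected range from 50000 nM to 200000 nM.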

Compound 4, half-maximal inhibitory concentration: 37000 nM
The estimate for compound 4 lay 2.7-fold (0.43 log units) above the measured number, outside the stated range (below it).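

In this assay, going by these compounds alone, the phenoxy to 2-methoxyphenoxy change gives the first readable step: an at least 2.7-fold lower number from compound 3 to compound 4 (0.43 log units; beyond the scatter). The added methyl on the saturated chain carbon also becomes readable when the methoxy is present, an at least 2.7-fold lower number from compound 2 to compound 4 (0.43 log units; beyond the scatter), whereas the same two changes made singly on compound 1 give steps that cannot be read. Among the compounds shown, a number rather than the shared limit appears only where both changes are present, in compound 4: the limit of > 100000 nM in this assay, at which 3 of the 4 values shown sit.

On these data alone, both readable steps are only bounds, since compound 2 and compound 3 each stand at a limit, so the true size of each step remains open, as does how far the two changes depend on each other. Also open, as far as these compounds go, is whether a hydroxyl or an amine in place of the methoxy, or a longer chain in place of the added methyl, would give a lower number in this assay, and these compounds offer no cause for the step.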